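Second ortho fluoro on the benzamide arm of compound 1

The source may hold more compounds than are shown below. What is called first, only, known or untested is meant among the compounds shown, and "the series" means these compounds.

Measured so far:
compound 1, `Nc1ccccc1NC(=O)c1ccc(CNC(=O)c2n[nH]cc2NC(=O)c2ccccc2F)cc1`, 2270 nM
compound 2, `COc1ccccc1C(=O)Nc1c[nH]nc1C(=O)NCc1ccc(C(=O)Nc2ccccc2N)cc1`, 2660 nM
compound 3, `Nc1ccccc1NC(=O)c1ccc(CNC(=O)c2n[nH]cc2NC(=O)c2c(Cl)cccc2Cl)cc1`, 1200 nM

In a functional assay on A-375 cells (Homo sapiens) for inhibition, read by CCK-8 assay, with a stated time of 72 h (a higher number here means a weaker inhibitor, a lower number a stronger inhibitor), compound 1 stands second highest of the three numbers. Its nearest neighbour is compound 2, where a 1.2-fold higher number from compound 1 to compound 2 (0.07 log units; within the scatter); the furthest is compound 3, where a 1.9-fold lower number from compound 1 to compound 3 (0.28 log units; within the scatter). Between compounds 2 and 3, a 2.2-fold lower number from compound 2 to compound 3 (0.35 log units; beyond the scatter).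

Compound 4, `Nc1ccccc1NC(=O)c1ccc(CNC(=O)c2n[nH]cc2NC(=O)c2c(F)cccc2F)cc1`, has not been measured. It differs from compound 1 in one place: fluoro in place of hydrogen on an aromatic carbon. The change sits on the aromatic carbon ortho to the large group and meta to the existing fluoro group, so that the 2-fluorophenyl becomes a 2,6-difluorophenyl.

Among the measured compounds shown here, the step that bears on it most is the one from compound 1 to compound 3, where a second halogen also enters at the same kind of position and the number fell, though within the scatter. The account therefore expects compound 4 to come out slightly lower than compound 1, with the estimated step of a 1.4-fold lower number from compound 1 to compound 4 (0.15 log units; within the scatter). Compound 4 is estimated at 1600 nM, within the range 800 nM to 3200 nM.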

Compound 4, half-maximal inhibitory concentration: 1700 nM
Compound 4: middle estimate off by 1.1-fold (0.03 log units), on the low side, within the range that was stated.
By their numbers in this assay, from the lowest: compounds 3, 4, 1 and 2 (each within the scatter of the next, the first and the last beyond it).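

In this assay, fluoro in place of hydrogen on this aromatic carbon, ortho to a large group, gives a 1.3-fold lower number from compound 1 to compound 4 (0.13 log units; within the scatter), so a second fluoro here cannot be told apart from the single one. The 2,6-difluorophenyl also stays close to both other arms, with a 1.4-fold higher number from compound 3 to compound 4 (0.15 log units; within the scatter) for the change from 2,6-dichlorophenyl and a 1.6-fold lower number from compound 2 to compound 4 (0.19 log units; within the scatter) for the change from 2-methoxyphenyl, so this new compound cannot be separated from either, although the step between those two arms is printed as beyond the scatter. Nothing measured here accounts for these small steps. The compounds shown leave open whether an amine or a carboxylic acid on this aromatic carbon would give a step beyond the scatter. They also leave open how the phenyl with no fluoro at all would compare with compound 1.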